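A few compounds are considered here, and "the series" means these few. Any claim that something is new, unique, unknown or untested is made for them only; others in the source may bear on it.

The study looks at a small set of compounds sharing one core, examined in a functional assay on HeLa cells (Homo sapiens) for cytotoxicity, read by MTT assay, with a stated time of 24 h; on this read-out lower numbers stand for stronger inhibition and higher numbers for weaker inhibition. Compound 1, with structure `C=CC1=C(C(=O)Nc2ccccc2)C(c2ccc(Cl)c(Cl)c2)OC1`, is reported in this assay only as a limit, > 100000 nM. Compound 2, with structure `C=CC1=C(C(=O)NCc2ccc(Cl)cc2)C(c2ccc(OC)cc2)OC1`, likewise gives only a limit in this assay, > 100000 nM. Compound 3, with structure `C=CC1=C(C(=O)NCc2ccccc2F)C(c2ccc(F)cc2)OC1`, also gives only a limit there, > 100000 nM. For the measured compounds named here, compound 2 therefore has no number of its own in this assay, and the two other values shown sit at the same limit; all three compounds rest at the limit of > 100000 nM in this assay, at which 3 of the 3 values shown sit, so no step between measured compounds can be read off.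

The piece follows the change from compound 2 to the not yet measured compound 4, whose structure is `C=CC1=C(C(=O)NCc2ccccc2)C(c2ccc(OC)cc2)OC1`. The difference is hydrogen in place of chloro on an aromatic carbon.

Going by the values given here, nothing among the measured compounds ties a hydrogen in place of chloro on an aromatic carbon to a shift in this assay, since every value shown is a limit. The step that the limit leaves unreadable from compound 2 to compound 4 is therefore expected to be none beyond the scatter. Compound 4 is expected to give 150000 nM, with a range from 50000 nM to 500000 nM, and most likely it too will be reported only as a limit.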

Compound 4, half-maximal inhibitory concentration: > 100000 nM
Compound 4: no number, only a limit; the forecaster's own chance of this, stated with the estimate: 85%; the middle value is on the limit's open side.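

Compound 4, like compound 2, is reported in this assay only as a limit, so no new step can be read between compound 2 and compound 4: the limit of > 100000 nM in this assay, at which 4 of the 4 values shown sit. The compounds shown leave open whether hydrogen in place of chloro on an aromatic carbon shifts this read-out at all, and what actual number any compound with the shared core would give.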